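This account rests on a few compounds, and the source may have more. Where it says the series, first, only, none or still open, it means among the compounds named here.

Measured so far: compound 1 `O=C(O)CCNC(=O)c1ccc(C(Oc2ccc(-n3cc(C(F)(F)F)cn3)cc2)C2CC2)cc1` with 1300 nM in an assay on cells for displacement of a labelled ligand from Glucagon receptor (Homo sapiens), in the presence of a further agent that is not named here; on this read-out higher numbers stand for weaker inhibition and lower numbers for stronger inhibition; compound 2 `CCCC(Oc1ccc(-n2cc3ccccc3n2)cc1)c1ccc(C(=O)NCCC(=O)O)cc1` with 290 nM; compound 3 `O=C(O)CCNC(=O)c1ccc(C(Oc2ccc(-n3cc(C(F)(F)F)cn3)cc2)C2CCC2)cc1` with 700 nM.

Compound 2 gives the lowest of the three numbers in this assay; compound 3 stands higher beyond the scatter, and compound 1 higher still. Among the compounds with values here, the only single-point step measured, a 1.9-fold lower number from compound 1 to compound 3 (0.27 log units; within the scatter), concerns the saturated chain carbon and not the aromatic substituent. Compound 4 `CCCC(Oc1ccc(-n2cc(C#N)cn2)cc1)c1ccc(C(=O)NCCC(=O)O)cc1` differs from compound 2 by 4-cyano-1H-pyrazol-1-yl in place of 2H-indazol-2-yl on an aromatic carbon. Within the data shown here, no measured step bears directly on this change; compounds 1 and 3 carry a different pyrazolyl group but also a different chain, so their values only show that such compounds sit at higher numbers than compound 2. Compound 4 is therefore expected to give a 2.1-fold higher number from compound 2 to compound 4 (0.32 log units; beyond the scatter). The estimate for compound 4 in this assay is 600 nM, within a range from 200 nM to 1800 nM.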

Compound 4, inhibition constant: 4100 nM
Compound 4: the middle estimate sits 6.8-fold (0.83 log units) below what was measured; measured number outside the range, above it.
By their numbers in this assay, from the lowest: compound 2; then compounds 3 and 1 (each within the scatter of the next); then compound 4.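

In this assay, putting 4-cyano-1H-pyrazol-1-yl in place of 2H-indazol-2-yl para to a large group gives a 14-fold higher number from compound 2 to compound 4 (1.15 log units; beyond the scatter) and so shows that this position responds strongly to the group it carries, which the earlier step on the saturated chain carbon could not show. The change removes the six-membered aromatic ring of carbon only and adds a nitrile at once. Nothing measured here accounts for the size of this step.

Open, as far as these compounds go, is where a plain 1H-pyrazol-1-yl, without the nitrile, would fall on the core of compound 4, and so how the step divides between the lost ring and the nitrile.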